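Chloro to Trifluoromethoxy: Expected Permeability of Compound 4

The source may report more compounds than this note shows. Statements on the series, on what has been measured and on what is new or still open speak of the compounds shown alone.

Three aryl ureas on a shared core have been measured in an ADME assay for permeability, using PAMPA, at pH 7.4; on this read-out lower numbers stand for lower permeability and higher numbers for higher permeability. Compound 1 `Cc1cc(NC(=O)Nc2ccccc2F)c2ccccc2n1` gives 817 10^-6 cm/s, compound 2 `Cc1cc(NC(=O)Nc2cccc(Cl)c2)c2ccccc2n1` gives 566 10^-6 cm/s, and compound 3 `Cc1cc(NC(=O)Nc2ccc(F)cc2)c2ccccc2n1` gives 801 10^-6 cm/s. Compound 2 stands lowest of the three numbers, yet a 1.4-fold higher number from compound 2 to compound 3 (0.15 log units; within the scatter) and a 1.4-fold lower number from compound 1 to compound 2 (0.16 log units; within the scatter) are both within the scatter, as is a 1.0-fold lower number from compound 1 to compound 3 (0.01 log units; within the scatter), so the three compounds cannot be separated on this assay.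

Compound 4 `Cc1cc(NC(=O)Nc2cccc(OC(F)(F)F)c2)c2ccccc2n1` has not been measured. It differs from compound 2 by trifluoromethoxy in place of chloro on an aromatic carbon. Among the compounds with values here, no measured step involves a trifluoromethoxy group; the steps that bear on the change are those in which the group on the six-membered aromatic ring of carbon only was exchanged, and every one of them stayed within the scatter. The account therefore expects a 1.1-fold lower number from compound 2 to compound 4 (0.04 log units; within the scatter), a step within the scatter. Compound 4 is estimated at 520 10^-6 cm/s, with an expected range from 300 10^-6 cm/s to 850 10^-6 cm/s.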

Compound 4, apparent permeability: 464 10^-6 cm/s
Estimate against measurement, compound 4: 1.1-fold (0.05 log units) above; low and high end bracket the measured number.
By their numbers in this assay, from the lowest: compounds 4, 2, 3 and 1 (each within the scatter of the next).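

Measured in this assay, the exchange on an aromatic carbon, meta to a large group, gives a 1.2-fold lower number from compound 2 to compound 4 (0.09 log units; within the scatter) and so stays within the usual scatter. The earlier compounds shown here showed only exchanges among fluoro and chloro groups on this ring, whereas here chloro, with 1 heavy atom and no hydrogen-bond acceptor, gives way to trifluoromethoxy, with 5 heavy atoms and 1 hydrogen-bond acceptor, and compound 2 and compound 4 still cannot be separated. No evidence on what lies behind this result is at hand.

Going by these compounds, all four compounds keep the shared core and carry only fluoro, chloro or trifluoromethoxy on this ring, so what an amine or a carboxylic acid in that place would give stays open. Whether trifluoromethoxy elsewhere on the ring would also stay within the scatter is open too.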